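Halogen Swaps at the Edge of a Cytotoxicity Assay

The source may report more compounds than this note shows. Statements on the series, on what has been measured and on what is new or still open speak of the compounds shown alone.

In a functional assay on K562 cells (Homo sapiens) for cytotoxicity, read by MTT assay, with a stated time of 24 h (on this read-out lower numbers stand for stronger inhibition and higher numbers for weaker inhibition), compound 1 `CN1C/C(=C\c2ccc(F)cc2)C(=O)/C(=C/c2cccc([N+](=O)[O-])c2)C1` gives 11300 nM. As far as these compounds go, compound 2 `CN1C/C(=C\c2ccc(Br)cc2)C(=O)/C(=C/c2cccc([N+](=O)[O-])c2)C1` returns only a limit, > 20000 nM, and not a number, so its true position remains unknown. The next compound to be tested, compound 3 `CN1C/C(=C\c2cccc([N+](=O)[O-])c2)C(=O)/C(=C/c2ccc(Cl)cc2Cl)C1`, differs from it in one place: 2,4-dichlorophenyl in place of 4-bromophenyl on a double-bonded chain carbon bound to a double-bonded ring carbon. This swap sits on a double-bonded chain carbon bound to a double-bonded ring carbon. Within the data shown here, the one measured step on that same ring, an at least 1.7-fold higher number from compound 1 to compound 2 (0.24 log units; that floor lies within the scatter), gives only a floor, so no step beyond the scatter is expected in this assay. That leaves the direction open, and the expected at least 1.3-fold lower number from compound 2 to compound 3 (0.12 log units; that floor lies within the scatter) should stay small. Compound 3 could also return only a limit. As a number, compound 3 is estimated at 15000 nM, with an expected range from 5000 nM to 35000 nM.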

Compound 3, half-maximal inhibitory concentration: 12400 nM
For compound 3 the middle estimate is 1.2-fold (0.08 log units) above the measured one, within the range that was stated.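

In this assay, 2,4-dichlorophenyl at this position returns a measured number, whereas 4-bromophenyl returned only a limit. The change from 4-bromophenyl to 2,4-dichlorophenyl gives an at least 1.6-fold lower number from compound 2 to compound 3 (0.20 log units; that floor lies within the scatter) and this is only a floor, so the true step could be larger, as compound 2 gives a limit and not a number: the limit of > 20000 nM in this assay, at which 1 of the 3 values shown sits. The change from 4-fluorophenyl to 2,4-dichlorophenyl gives a 1.1-fold higher number from compound 1 to compound 3 (0.04 log units; within the scatter) and so these two groups cannot be told apart here, although one ring carries a single halogen and the other carries two.

As far as these compounds go, how far compound 2 truly lies from the other two compounds stays open. Every group shown at this position is a halogen-bearing phenyl ring, so it remains unknown how a phenyl ring carrying an amine or a carboxylic acid would read in this assay.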